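Pyrazine for Pyridine on the Amide Nitrogen

The source may hold more compounds than are shown below. What is called first, only, known or untested is meant among the compounds shown, and "the series" means these compounds.

Compound 1, `CCN(CC)C(=O)CN(c1ccc(C)cc1)S(=O)(=O)c1cccc(Cl)c1`, gives 139 nM in a functional assay on CHO cells for inhibition of Orexin receptor type 2 (Homo sapiens), read by FLIPR and calcium flux; on this read-out lower numbers stand for stronger inhibition and higher numbers for weaker inhibition.
Compound 2, `CCN(C(=O)CN(c1cc(N(C)C)ccc1Cl)S(=O)(=O)c1ccc(OC)c(OC)c1)c1cccc(C)n1`, gives 5 nM.

Of the two measured compounds, compound 2 carries the lower number in this assay, and compound 1 sits well above it. Going by these compounds, compound 3, `CCN(C(=O)CN(c1cc(N(C)C)ccc1Cl)S(=O)(=O)c1ccc(OC)c(OC)c1)c1cnc(C)cn1`, is untested; it differs from compound 2 in one place: 5-methylpyrazin-2-yl in place of 6-methylpyridin-2-yl on an amide-type nitrogen. Among the measured compounds shown here, no measured pair shows this exchange, so the expected step of a 1.6-fold higher number from compound 2 to compound 3 (0.20 log units; within the scatter) is judged small, with no direction beyond the scatter. For compound 3 the value in this assay is estimated at 8 nM, expected between 3 nM and 25 nM.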

Compound 3, half-maximal inhibitory concentration: 3 nM
Compound 3: middle estimate off by 2.7-fold (0.43 log units), on the high side; low and high end bracket the measured number.
By their numbers in this assay, from the lowest: compounds 3 and 2 (each within the scatter of the next); then compound 1.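

On the amide-type nitrogen, 5-methylpyrazin-2-yl in place of 6-methylpyridin-2-yl gives a 1.7-fold lower number from compound 2 to compound 3 (0.22 log units; within the scatter) in this assay. This position therefore accepts a ring with 2 hetero atoms and 2 hydrogen-bond acceptors in place of one with 1 of each, with no difference that this read-out can resolve. Nothing measured here gives a cause for this result. The compounds shown leave open how a plain phenyl or a pyrimidin-2-yl would read on the same nitrogen. They also leave open what an amine or a carboxylic acid on the ring would do.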